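Sulfonyl in place of ethyl on the amine nitrogen

The source may report more compounds than this note shows. Statements on the series, on what has been measured and on what is new or still open speak of the compounds shown alone.

In a functional assay on HeLa cells (Homo sapiens) for antiproliferative activity, read by MTT assay, with a stated time of 48 h (a lower number here means a stronger inhibitor, a higher number a weaker inhibitor), compound 1 (`CCNc1ccc2ncc(-c3cnn(C)c3)cc2n1`) gives > 50000 nM as a limit of the assay, not a number. Compound 2 (`COc1ccc(CNc2ccc3ncc(-c4cnn(C)c4)cc3n2)cc1`) gives > 50000 nM in this assay as a limit too. Compound 1 thus stands at the limit of > 50000 nM in this assay, at which 2 of the 2 values shown sit, and has no number of its own.

Compound 3 (`Cn1cc(-c2cnc3ccc(NS(=O)(=O)c4cccs4)nc3c2)cn1`) carries (thiophen-2-yl)sulfonyl in place of ethyl on a nitrogen on an aromatic ring on the shared core. For the measured compounds named here, the only measured step that bears on this change is a step that the two limits leave unreadable from compound 1 to compound 2 and it offers no size to carry over. With no measured gain in the series, only a small move towards stronger inhibition is expected. The expected change is an at least 1.4-fold lower number from compound 1 to compound 3 (0.15 log units; that floor lies within the scatter) in this assay and it remains uncertain. For compound 3 the estimate is 35000 nM with an expected range from 6000 nM to 50000 nM and another limit remains likely.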

Compound 3, half-maximal inhibitory concentration: 38400 nM
Compound 3: the middle estimate sits 1.1-fold (0.04 log units) below what was measured, within the range that was stated.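

Compound 3 is the only compound shown that gives a measured number, 38400 nM in this assay. The other two values stay at the limit: the limit of > 50000 nM in this assay, at which 2 of the 3 values shown sit. For the compounds shown here, at this nitrogen on an aromatic ring, (thiophen-2-yl)sulfonyl in place of ethyl therefore gives the first step that can be read, an at least 1.3-fold lower number from compound 1 to compound 3 (0.11 log units; that floor lies within the scatter), whereas the change to 4-methoxyphenyl gave no readable step. Compound 1 has only a limit, so this step is a floor and its full size cannot be read.

The compounds shown leave open whether the sulfonyl link or the thiophene ring accounts for the step. A methylsulfonyl or phenylsulfonyl group on the same nitrogen would separate the two parts, and an acetyl group would test the need for the sulfonyl.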